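This account rests on a few compounds, and the source may have more. Where it says the series, first, only, none or still open, it means among the compounds named here.

In a functional assay on Bel-7402 cells (Homo sapiens) for inhibition, read by MTT assay, with a stated time of 24 h, tested at 0.1 ug/mL (on this read-out lower numbers stand for less inhibition of growth and higher numbers for more inhibition of growth at the one concentration tested), compound 1 `O=C(CCCCC1CCSS1)Nc1cccc(C(F)(F)F)c1` is recorded as "not active" (no number reported) without a number. Compound 2 `O=C(CCCCC1CCSS1)Nc1ccc([N+](=O)[O-])c(C(F)(F)F)c1` gives 5.04% and compound 3 `O=C(CCCCC1CCSS1)Nc1ccccn1` gives 0.89% in the same test. These two values lie within the scatter of each other, so the numbers do not separate compound 2 from compound 3. Compound 4 `O=C(CCCCC(S)CCS)Nc1ccc([N+](=O)[O-])c(C(F)(F)F)c1` is still unmeasured, and its change from compound 2 is a group of 5 heavy atoms (3 carbon, 2 sulfur; no ring) in place of a group of 5 heavy atoms (3 carbon, 2 sulfur; one five-membered non-aromatic ring with 2 hetero atoms), on a saturated chain carbon, four bonds along the chain from a carbonyl carbon with 1,3-disulfanylpropyl replacing the one five-membered non-aromatic ring. Within the data shown here, no measured pair shows this change, so no step beyond the scatter is expected in this assay in either direction. The estimated step of a number 1 percentage points higher from compound 2 to compound 4 (within the scatter) stays within that scatter. Compound 4 is expected at 6% with an estimated range from 0% to 15% in this read-out.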

Compound 4, percent growth inhibition at one concentration: 6.54%
Compound 4: middle estimate off by 0.5 percentage points, on the low side, and the stated range covers the measured number.
By their numbers in this assay, from the lowest: compounds 3, 2 and 4 (each within the scatter of the next).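

Within this assay the replacement of the five-membered non-aromatic ring with 2 hetero atoms by 1,3-disulfanylpropyl, on a saturated chain carbon, four bonds along the chain from a carbonyl carbon, gives a number 1.5 percentage points higher from compound 2 to compound 4 (within the scatter). At this position, the ring and the open group are therefore not separated at the one concentration tested, although 0 hydrogen-bond donors become 2. No other data bear on this result.

Going by these compounds, whether an amine, a carboxylic acid or a longer chain at this carbon would give a step beyond the scatter remains open. On these data alone, the same change on the core of compound 3 is also open.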